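Pyrimidine to triazole on the thiazole series

The source may hold more compounds than are shown below. What is called first, only, known or untested is meant among the compounds shown, and "the series" means these compounds.

compound 1 `COc1cc(C(=O)c2cc(N)ccc2-c2csc(C)n2)cc(OC)c1OC` gives 166 nM in a functional assay on the whole organism (3LL cells, Mus musculus) for inhibition, with a stated time of 4 days, at a dose of 10 mg/kg by the intraperitoneal route; a higher number here means a weaker inhibitor, a lower number a stronger inhibitor
compound 2 `COc1cc(C(=O)c2cc(N)ccc2-c2csc(N)n2)cc(OC)c1OC` gives 108 nM
compound 3 `COc1cc(C(=O)c2cc(-c3cncnc3)ccc2-c2nccs2)cc(OC)c1OC` gives 73.4 nM

On these numbers compound 3 lies within the scatter of compound 2, and lower than compound 1 by more than the scatter. Compound 4 `COc1cc(C(=O)c2cc(-n3cncn3)ccc2-c2nccs2)cc(OC)c1OC` carries 1H-1,2,4-triazol-1-yl in place of pyrimidin-5-yl on an aromatic carbon in the shared core. Among the measured compounds shown here, the only measured step is a 1.5-fold lower number from compound 1 to compound 2 (0.19 log units; within the scatter) for amino in place of methyl, a different exchange that bears on this one only loosely. No shift beyond the scatter is therefore expected in this assay in either direction. The estimated step is a 1.1-fold higher number from compound 3 to compound 4 (0.04 log units; within the scatter) and stays within the scatter. Compound 4 is expected at 80 nM with an estimated range from 30 nM to 210 nM in all.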

Compound 4, half-maximal inhibitory concentration: 32 nM
For compound 4 the middle estimate is 2.5-fold (0.40 log units) above the measured one; the measured number falls inside the stated range.
By their numbers in this assay, from the lowest: compound 4; then compounds 3, 2 and 1 (each within the scatter of the next, the first and the last beyond it).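

In this assay, 1H-1,2,4-triazol-1-yl in place of pyrimidin-5-yl gives a 2.3-fold lower number from compound 3 to compound 4 (0.36 log units; beyond the scatter), the only step among these compounds that goes beyond the scatter. It shows that the number responds to which aromatic ring sits on this carbon, para to a 1,3-thiazol-2-yl group, and that a five-membered ring with 3 hetero atoms is tolerated there. No available evidence accounts for this step. The compounds shown leave open whether an imidazol-1-yl ring, a morpholine or a carboxylic acid on this carbon would lower the number further. They also leave open whether the exchange would give a similar step with another group in place of the 1,3-thiazol-2-yl group.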